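Acetyl to Hydroxymethyl on a Dithiocarbamate Chain

A few compounds are considered here, and "the series" means these few. Any claim that something is new, unique, unknown or untested is made for them only; others in the source may bear on it.

Compound 1 `N#CCCSC(=S)NCc1cccnc1` — 2840 nM
Compound 2 `CC(=O)CCSC(=S)NCc1cccnc1` — 1120 nM

Of the compounds shown here, two have been measured in a functional assay on SK-BR-3 cells (Homo sapiens) for cytotoxicity, read by resazurin assay, with a stated time of 72 h; a higher number here means a weaker inhibitor, a lower number a stronger inhibitor. Compound 1 `N#CCCSC(=S)NCc1cccnc1` gives 2840 nM, and compound 2 `CC(=O)CCSC(=S)NCc1cccnc1` gives 1120 nM. Compound 2 stands at the lower of the two numbers, and the step of a 2.5-fold lower number from compound 1 to compound 2 (0.40 log units; beyond the scatter) lies beyond the scatter.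

The next compound, compound 3 `OCCCSC(=S)NCc1cccnc1`, changes the same position again: hydroxymethyl in place of acetyl on a saturated chain carbon, two bonds along the chain from a sulfur. Going by the values given here, the only measured step, a 2.5-fold lower number from compound 1 to compound 2 (0.40 log units; beyond the scatter), exchanges one chain terminus for another at this carbon and shows that this position tolerates change, but it does not involve a hydroxyl group, so no measured step bears directly on the new change. The acetyl of compound 2 has been the better of the two termini seen so far; removing it leaves the direction open.

Compound 3 is therefore expected to land near compound 2, with a modest step of a 1.6-fold higher number from compound 2 to compound 3 (0.21 log units; within the scatter) possible in either direction. The estimate for compound 3 in this assay is 1800 nM, within a range from 700 nM to 4500 nM.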

Compound 3, half-maximal inhibitory concentration: 1320 nM
Compound 3: the middle estimate sits 1.4-fold (0.13 log units) above what was measured; measured number inside the range.
By their numbers in this assay, from the lowest: compounds 2 and 3 (each within the scatter of the next); then compound 1.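

In this assay, putting hydroxymethyl in place of acetyl brings in a hydrogen-bond donor and removes a double bond outside aromatic rings, yet it gives a 1.2-fold higher number from compound 2 to compound 3 (0.07 log units; within the scatter), so these two chain termini cannot be told apart at this position, something the earlier pair could not show. The cyano terminus of compound 1 now stands apart from both others: the new comparison gives a 2.2-fold lower number from compound 1 to compound 3 (0.33 log units; beyond the scatter), so the gap seen earlier is not particular to acetyl but also appears with a second terminus, among these three compounds only. Nothing available here explains why the cyano terminus differs from the other two or why acetyl and hydroxymethyl match.

These compounds leave open whether the same level holds for termini of another kind, such as an amine or a carboxylic acid at this chain carbon, or whether either would move the number in one direction. They also leave open whether the hydroxyl group keeps this level on a longer chain than the 3-hydroxypropyl of compound 3, and whether any terminus can go further than the level shared by compound 2 and compound 3.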